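The source may report more compounds than this note shows. Statements on the series, on what has been measured and on what is new or still open speak of the compounds shown alone.

Two related compounds have been tested so far in a functional assay on A549 cells (Homo sapiens) for cytotoxicity, read by MTT assay, with a stated time of 72 h; a lower number here means a stronger inhibitor, a higher number a weaker inhibitor. Compound 1 `COc1cccc(/C=C2\CCC/C(=C\c3ccccc3Br)C2=O)c1OC` gives > 20000 nM, which is a limit of the assay and not a number. For the measured compounds named here, compound 2 `COc1ccc(/C=C2\CCC/C(=C\c3cccc(Cl)c3)C2=O)cc1OC` gives 11000 nM, the only true number available.

Compound 3 `COc1ccc(/C=C2\CCC/C(=C\c3cccc(Br)c3)C2=O)cc1OC` has not yet been measured. It keeps the structure of compound 2 except at one place: bromo in place of chloro on an aromatic carbon. Bromo takes the place of chloro on an aromatic carbon, meta to a large group, so that 3-chlorophenyl becomes 3-bromophenyl.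

Going by the values given here, no two measured compounds differ in just one place, so the data give no direct guide to the size of a single change in this assay. This swap replaces only one heavy atom with another, so starting from compound 2 at 11000 nM, no shift beyond the usual scatter is expected, in either direction. The estimated change, a 1.1-fold lower number from compound 2 to compound 3 (0.04 log units; within the scatter), is therefore small. Compound 3 is expected at about 10000 nM, with an estimated range of 5000 nM to 20000 nM.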

Compound 3, half-maximal inhibitory concentration: 12800 nM
Compound 3: middle estimate off by 1.3-fold (0.11 log units), on the low side, and the stated range covers the measured number.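

For the compounds shown here, exchanging 3-chlorophenyl for 3-bromophenyl gives the first single change that can be sized in this assay, and it amounts to a 1.2-fold higher number from compound 2 to compound 3 (0.07 log units; within the scatter). At this place on the aromatic ring, then, this measurement does not tell bromo and chloro apart, a finding that holds for this one pair and reaches no further. The earlier compounds shown here could not show this, as no two of them differed in just one place, and it means that exchanging one halogen atom for the other here brings no gain in cytotoxicity on these cells.

From the compounds shown here alone, whether this place on the ring matters at all stays open, as two halogens say nothing about what an amine, a carboxylic acid or a longer chain would do there. Compound 1 differs from compound 2 in more than one place and stands at a limit, not a number, which leaves no single change readable from it: the limit of > 20000 nM in this assay, at which 1 of the 3 values shown sits.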